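The Piperazine Arm Gives Way to a Larger Group

The source may hold more compounds than are shown below. What is called first, only, known or untested is meant among the compounds shown, and "the series" means these compounds.

Compound 3 `CN1CCN(Cc2nc3ccccc3c(-c3ccccc3)c2C(=O)NCc2cc(C(F)(F)F)cc(C(F)(F)F)c2)CC1` sits at the ceiling of an in vitro assay on UC11MG cells for binding affinity to Substance-P receptor (Homo sapiens), read by radioligand binding (on this read-out lower numbers stand for stronger inhibition and higher numbers for weaker inhibition), where it returns > 1000 nM, a limit of the assay rather than a number. Compound 1 `O=C(NCc1cc(C(F)(F)F)cc(C(F)(F)F)c1)c1cnc2ccccc2c1-c1ccccc1` likewise returns only a limit, > 1000 nM. Compound 2 `O=C(NCc1cc(C(F)(F)F)cc(C(F)(F)F)c1)c1c(CBr)nc2ccccc2c1-c1ccccc1`, which bears bromomethyl, gives 0.01 nM. The change an at least 100000-fold lower number from compound 1 to compound 2 (5.00 log units; beyond the scatter) is large, an at least 100000-fold higher number from compound 2 to compound 3 (5.00 log units; beyond the scatter) undoes it, and a step that the two limits leave unreadable from compound 1 to compound 3 cannot be sized because of the limit of > 1000 nM in this assay, at which 2 of the 3 values shown sit. Compound 4 `O=C(NCc1cc(C(F)(F)F)cc(C(F)(F)F)c1)c1c(CN2C(=O)c3ccccc3C2=O)nc2ccccc2c1-c1ccccc1` carries a group of 11 heavy atoms (8 carbon, 1 nitrogen, 2 oxygen; one five-membered non-aromatic ring with 1 hetero atom, one six-membered aromatic ring of carbon only) in place of a group of 7 heavy atoms (5 carbon, 2 nitrogen; one six-membered non-aromatic ring with 2 hetero atoms), on a saturated chain carbon bound to an aromatic carbon. Within the data shown here, no measured pair compares these two groups, so the neighbouring steps leave the direction open. Compound 4 is expected to stay weak, with an at least 2.0-fold lower number from compound 3 to compound 4 (0.30 log units; that floor lies within the scatter) and an estimated value of 500 nM, ranging from 20 nM to 5000 nM.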

Compound 4, half-maximal inhibitory concentration: > 1000 nM
Compound 4 ended at the assay's limit (the forecaster's own chance of this, stated with the estimate: 55%); middle value at least 2.0-fold (0.30 log units) from the limit.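

In this assay, the group of 11 heavy atoms in compound 4 joins the 4-methylpiperazin-1-yl of compound 3 as a second replacement for bromine on the saturated chain carbon that does not keep the low number of compound 2 (an at least 100000-fold higher number from compound 2 to compound 4 (5.00 log units; beyond the scatter)). Among the compounds shown, that low number therefore belongs to the bromomethyl compound alone. The steps from compound 3 to compound 4 and from compound 1 to compound 4 cannot be read because both ends are limits: (the limit of > 1000 nM in this assay, at which 3 of the 4 values shown sit).

On these data alone, whether a chlorine atom, a hydroxyl or a methoxy on that carbon would keep any of the strength of compound 2 stays open. As far as these compounds go, how compound 3 and compound 4 rank against each other also stays open.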